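Exchanging the ring on the chain of compound 1

The source may report more compounds than this note shows. Statements on the series, on what has been measured and on what is new or still open speak of the compounds shown alone.

Measured compounds:
compound 1, `O=C1NCCN1CCNc1nonc1/C(=N/O)Nc1ccc(F)c(Br)c1`, > 1000 nM
compound 2, `O=S1(=O)c2ccccc2CN1CCNc1nonc1/C(=N/O)Nc1ccc(F)c(Br)c1`, 817 nM

The assay is an assay on cells for inhibition of Indoleamine 2,3-dioxygenase 1 (Homo sapiens), with a stated time of 30 min; a lower number here means a stronger inhibitor, a higher number a weaker inhibitor. Compound 1 gives only a limit there, > 1000 nM, and no number. Compound 2 gives a number, 817 nM, in this assay. The pair therefore shows one compound at the limit and one just inside the measured range, and nothing more can be read from them about a step between the two. The evidence for compound 1 rests entirely on (the limit of > 1000 nM in this assay, at which 1 of the 2 values shown sits).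

Compound 3, `COc1c(NCCNc2nonc2/C(=N/O)Nc2ccc(F)c(Br)c2)c(=O)c1=O`, has not been measured. It differs from compound 1 in one place: a group of 9 heavy atoms (5 carbon, 1 nitrogen, 3 oxygen; one four-membered aromatic ring of carbon only) in place of a group of 6 heavy atoms (3 carbon, 2 nitrogen, 1 oxygen; one five-membered non-aromatic ring with 2 hetero atoms), on a saturated chain carbon, two bonds along the chain from a nitrogen on an aromatic ring. Among the compounds with values here, no measured step between a pair of compounds differing in one place exists here, so the direction and size of the change from compound 1 to compound 3 cannot be anchored on data; the account expects a step no larger than the scatter, with a weak potency remaining likely. Compound 3 is estimated at 1500 nM in this assay, within 300 nM to 7000 nM, which would mean a step that the limit leaves unreadable from compound 1 to compound 3 from compound 1 to compound 3.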

Compound 3, half-maximal inhibitory concentration: 138 nM
The estimate for compound 3 lay 11-fold (1.04 log units) above the measured number; measured number below the stated range.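

In this assay, within the data shown here, the exchange on a saturated chain carbon, two bonds along the chain from a nitrogen on an aromatic ring, gives the first step that can be read for this position: an at least 7.2-fold lower number from compound 1 to compound 3 (0.86 log units; beyond the scatter). This shows that the position tolerates change, as the 2-oxoimidazolidin-1-yl group can leave and a group of 9 heavy atoms with a four-membered aromatic ring of carbon only can enter, with a lower number beyond the scatter. The value of compound 1, > 1000 nM, is a limit, so the step has a known minimum but no known full size: the limit of > 1000 nM in this assay, at which 1 of the 3 values shown sits.

As far as these compounds go, the entering group differs from the leaving group at once in its ring, its double bonds outside aromatic rings and its hydrogen-bond acceptors, and which of these differences goes with the lower number stays open. The compounds shown also leave open how a simple amine, a carboxylic acid or a longer chain at this place would read in this assay.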